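A few compounds are considered here, and "the series" means these few. Any claim that something is new, unique, unknown or untested is made for them only; others in the source may bear on it.

Compound 2, `CCCS(=O)(=O)Nc1ccc(F)c(C(=O)c2n[nH]c3ncc(-c4ccc(OC)cc4)cc23)c1F`, was tested in an assay for binding affinity to dual specificity mitogen-activated protein kinase kinase 4 (Homo sapiens), read by KINOMEscan, tested at 100 nM; a lower number here means a stronger effect, a higher number a weaker effect of the compound at the concentration tested. In this assay compound 2 gives 4.2%, the higher of the two numbers recorded so far, yet its distance from compound 1 lies within the scatter of repeated measurements. Compound 1, `CCCS(=O)(=O)Nc1ccc(F)c(C(=O)c2n[nH]c3ncc(-c4ccccc4)cc23)c1F`, gives 2.4%. Among the measured compounds shown here, the only measured step, a number 1.8 percentage points higher from compound 1 to compound 2 (within the scatter), placed a methoxy group on an aromatic carbon and left the read-out essentially unchanged.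

Compound 3, `CCCS(=O)(=O)Nc1ccc(F)c(C(=O)c2n[nH]c3ncc(-c4ccc(N(C)C)cc4)cc23)c1F`, has not been measured. It differs from compound 2 at that same place: dimethylamino in place of methoxy on an aromatic carbon. For the measured compounds named here, the one measured step bears on this change only loosely. It shows that adding a small group on this aromatic carbon, para to a large group, did not move the number beyond the scatter. Swapping one small group for another at the same place is therefore expected to give no step beyond the scatter, and a number 0.8 percentage points higher from compound 2 to compound 3 (within the scatter) is the expected size of that step. The estimate for compound 3 in this assay is 5%, with a range from 1% to 15%.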

Compound 3, a percentage reported as activity, at one concentration (the size of the read-out at that concentration, not a potency): 2.5%
Compound 3: middle estimate off by 2.5 percentage points, on the high side; low and high end bracket the measured number.
By their numbers in this assay, from the lowest: compounds 1, 3 and 2 (each within the scatter of the next).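

In this assay, exchanging methoxy for dimethylamino on this aromatic carbon, para to a large group, gives a number 1.7 percentage points lower from compound 2 to compound 3 (within the scatter), so a second kind of group now sits at this place with no step beyond the scatter. Among the compounds shown here, measured against the parent with only hydrogen at this carbon, dimethylamino in place of hydrogen gives a number 0.1 percentage points higher from compound 1 to compound 3 (within the scatter), which means that an oxygen-linked group and a nitrogen-linked group have each been placed here with no step from hydrogen beyond the scatter. No measurement shown explains why the read-out is so tolerant of these exchanges at this place.

Still open, going by these compounds, is whether a carboxylic acid, a primary amine or a longer chain such as hexyloxy on this same carbon would also stay within the scatter, since all the groups seen here are small and uncharged. Each read-out also gives only the size of the effect at a single concentration, so these numbers cannot tell whether these three closely matched compounds would show a stronger or weaker effect than one another at any other concentration.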